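Compound 3: 1H-pyrazol-1-yl replaces 2-methyl-1H-imidazol-1-yl

The source may hold more compounds than are shown below. What is called first, only, known or untested is meant among the compounds shown, and "the series" means these compounds.

Measured so far in a functional assay on HUVEC cells (Homo sapiens), read by scintillation counting and thymidine incorporation, with a stated time of 24 h; on this read-out lower numbers stand for stronger inhibition and higher numbers for weaker inhibition
- compound 1 `CCC(C)n1ncn(-c2ccc(N3CCN(c4ccc(OC[C@@H]5CO[C@@](Cn6nc(C)nc6C)(c6ccc(Cl)cc6Cl)O5)cc4)CC3)cc2)c1=O` gives 221 nM
- compound 2 `CCC(C)n1ncn(-c2ccc(N3CCN(c4ccc(OC[C@@H]5CO[C@@](Cn6ccnc6C)(c6ccc(Cl)cc6Cl)O5)cc4)CC3)cc2)c1=O` gives 173 nM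

Within the data shown here, compound 2 stands level with compound 1, the only other compound measured (a 1.3-fold lower number from compound 1 to compound 2 (0.11 log units; within the scatter)). Compound 3 `CCC(C)n1ncn(-c2ccc(N3CCN(c4ccc(OC[C@@H]5CO[C@@](Cn6cccn6)(c6ccc(Cl)cc6Cl)O5)cc4)CC3)cc2)c1=O` carries 1H-pyrazol-1-yl in place of 2-methyl-1H-imidazol-1-yl on a saturated chain carbon bound to a saturated ring carbon and is still unmeasured. Among the measured compounds shown here, only one measured step exchanges a group at this place, and it stayed within the scatter (a 1.3-fold lower number from compound 1 to compound 2 (0.11 log units; within the scatter)). No step beyond the scatter is therefore expected in this assay, and no direction is firm (estimated step: a 1.2-fold higher number from compound 2 to compound 3 (0.06 log units; within the scatter)). Compound 3 is estimated at 200 nM (expected range 90 nM to 450 nM).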

Compound 3, half-maximal inhibitory concentration: 307 nM
For compound 3 the middle estimate is 1.5-fold (0.19 log units) below the measured one; the measured number falls inside the stated range.
By their numbers in this assay, from the lowest: compounds 2, 1 and 3 (each within the scatter of the next).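

In this assay, a 1.8-fold higher number from compound 2 to compound 3 (0.25 log units; within the scatter), and a 1.4-fold higher number from compound 1 to compound 3 (0.14 log units; within the scatter). Thus, among these compounds, the three different five-membered aromatic rings on the saturated chain carbon cannot be told apart, and 1H-pyrazol-1-yl, which has no methyl group, stays within the scatter of both methylated rings. Nothing available explains these numbers.

The compounds shown leave open whether an open-chain amine, a carboxylic acid or a pyridine ring at this place would stay within the same scatter in this assay.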